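Swapping the pyridine ring on a weakly active amide scaffold

The source may report more compounds than this note shows. Statements on the series, on what has been measured and on what is new or still open speak of the compounds shown alone.

Measured compounds:
- compound 1 `O=C(Nc1cc(C(F)(F)F)ccc1N1CCCC1)c1ccncc1`: "not active" (no number reported)
- compound 2 `O=C(Nc1cc(C(F)(F)F)ccc1N1CCCCC1)c1ccccc1`: "not active" (no number reported)
- compound 3 `CCN(CC)c1ccc(C(F)(F)F)cc1NC(=O)c1ccncc1`: 89700 nM

All three measured compounds were tested in a functional assay on HL-60 cells (Homo sapiens) for cytotoxicity, read by MTT assay, with a stated time of 48 h; on this read-out lower numbers stand for stronger inhibition and higher numbers for weaker inhibition. Compound 1 is recorded there as "not active" (no number reported), with no number attached, and compound 2 likewise gives "not active" (no number reported), so no single number places either of them on the scale. Only compound 3 has a number in this assay, 89700 nM, and that number lies at the weak end of what the read-out covers. Taken together, the three results show a series in which cytotoxicity toward these cells is at best faint.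

Compound 4 `O=C(Nc1cc(C(F)(F)F)ccc1N1CCCC1)c1cccnc1Cl` has not yet been measured. It differs from compound 1 in one place: 2-chloropyridin-3-yl in place of pyridin-4-yl on a carbonyl carbon. Among the compounds with values here, no step between measured compounds is known for this kind of change, so there is nothing to scale an expectation against beyond the fact that compound 1 itself produced no number and compound 3, the only numbered neighbour, sits near the top of the range.

Compound 4 is therefore expected to remain weak, with an estimated value of 80000 nM and a likely range from 20000 nM to 300000 nM, and a real chance that, as with compound 1, no number is reported at all.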

Compound 4, half-maximal inhibitory concentration: "not active" (no number reported)
For compound 4 the study gives words and no number; there is nothing to compare the estimate with.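

In this assay compound 1 and compound 4 are both recorded as not active, with no number attached, so no step can be read between them. The compounds shown leave open whether 2-chloropyridin-3-yl in place of pyridin-4-yl changes cytotoxicity at all. No measurement shown bears on the reason for this result.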